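Acid-tail replacement on the spirocyclic amide series

The compounds below may be only part of what the source reports. "The series", "measured", "known", "first", "only" and "open" are said of these compounds alone.

Measured so far in this series:
compound 1 `CC(C)(C)c1ccc(C(=O)N2CCC3(CC2)C(=O)N(CC(=O)NCCC(=O)O)CN3c2ccccc2)cc1` 11400 nM
compound 2 `O=C(CN1CN(c2ccccc2)C2(CCN(C(=O)c3ccc(C4CCCCC4)cc3)CC2)C1=O)N1CCC(CO)CC1` 1100 nM
compound 3 `CC(C)(C)OC(=O)NCCCCNC(=O)CN1CN(c2ccccc2)C2(CCN(C(=O)c3ccc(C4CCCCC4)cc3)CC2)C1=O` 4600 nM

Three compounds have numbers in an assay on HEK293 cells for displacement of a labelled ligand from NPC1-like intracellular cholesterol transporter 1 (Homo sapiens); on this read-out higher numbers stand for weaker inhibition and lower numbers for stronger inhibition. Compound 1, carrying a carboxy-terminated tail on the shared core, gives 11400 nM, the highest of the three. Compound 3 gives 4600 nM, a gap beyond the scatter, and compound 2 gives 1100 nM, the furthest from compound 1. Compounds 2 and 3 differ from compound 1 in more than one place, so none of these pairs counts as a single step; their values can only be read as they stand.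

Compound 4 `CC(C)(C)c1ccc(C(=O)N2CCC3(CC2)C(=O)N(CC(=O)NCCCCNS(C)(=O)=O)CN3c2ccccc2)cc1` differs from compound 1 in one place: 2-(methanesulfonamido)ethyl in place of carboxy on a saturated chain carbon, two bonds along the chain from an amide-type nitrogen. Among the measured compounds shown here, no measured pair shows this change or anything close to it, so the expectation rests on the values alone: the only carboxy-bearing compound has the highest number, and the two compounds with other tails read lower. On that basis the step is expected to be a modest move to lower numbers, a 2.3-fold lower number from compound 1 to compound 4 (0.36 log units; beyond the scatter), with wide uncertainty. Compound 4 is estimated at 5000 nM, with a range from 1500 nM to 16000 nM.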

Compound 4, half-maximal inhibitory concentration: 4500 nM
The estimate for compound 4 lay 1.1-fold (0.05 log units) above the measured number; the range from low to high includes it.
By their numbers in this assay, from the lowest: compound 2; then compounds 4 and 3 (each within the scatter of the next); then compound 1.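

In this assay the series now has its first single-place step: 2-(methanesulfonamido)ethyl in place of carboxy on a saturated chain carbon, two bonds along the chain from an amide-type nitrogen, gives a 2.5-fold lower number from compound 1 to compound 4 (0.40 log units; beyond the scatter). The carboxy group is therefore not needed at this position for the number reached by compound 1, and the position accepts a larger group, with 7 heavy atoms entering and 3 leaving, without the number rising. No measurement shown here accounts for the size or direction of this step.

The change replaces the end group and lengthens the chain at once, so this single step cannot separate the two; the same difference also reads as 2-carboxyethyl to 4-(methanesulfonamido)butyl. A 4-carboxybutyl tail on the core of compound 1 would test the chain length alone, while a 4-aminobutyl tail would show whether the methanesulfonamido end itself matters to the step.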